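The source may hold more compounds than are shown below. What is called first, only, known or untested is meant among the compounds shown, and "the series" means these compounds.

Measured so far:
- compound 1 `CC1CCCCN1C(=S)SCc1ccc(C(=O)Nc2ccccc2N)cc1`: 76.3%
- compound 2 `Nc1ccccc1NC(=O)c1ccc(CSC(=S)N2CCN(c3ccncc3)CC2)cc1`: 77.4%

In a functional assay on HeLa cells (Homo sapiens) for antiproliferative activity, read by CCK-8 assay, with a stated time of 72 h, tested at 8 uM (on this read-out lower numbers stand for a weaker effect and higher numbers for a stronger effect at the one concentration tested), compound 1 gives 76.3%, and compound 2 gives 77.4%; the two values sit within the usual scatter of each other, so neither can be set apart from the other. Compound 3 `Nc1ccccc1NC(=O)c1ccc(CSC(=S)N2CCCC2)cc1` shares the core of compound 1 and differs from it in one place: pyrrolidin-1-yl in place of 2-methylpiperidin-1-yl on a thiocarbonyl carbon. For the measured compounds named here, no measured pair shows what such a change does here. With the two measured values so close, the expectation for compound 3 is a step of a number 2.3 percentage points lower from compound 1 to compound 3 (within the scatter), that is, nothing beyond the scatter, and an estimated value of 74%, ranging from 60% to 85%.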

Compound 3, a percentage reported as inhibition, at one concentration (the size of the read-out at that concentration, not a potency): 77.8%
Compound 3: the middle estimate sits 3.8 percentage points below what was measured; low and high end bracket the measured number.
By their numbers in this assay, from the lowest: compounds 1, 2 and 3 (each within the scatter of the next).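

In this assay, for the compounds shown here, pyrrolidin-1-yl in place of 2-methylpiperidin-1-yl on a thiocarbonyl carbon gives a number 1.5 percentage points higher from compound 1 to compound 3 (within the scatter) as the first step that can be read at this position. At the one concentration tested, compound 1 and compound 3 cannot be told apart, although the ring that enters has 5 heavy atoms and the ring that leaves has 7. Nothing available explains this result.

From the compounds shown here alone, whether an open-chain diethylamino group or a morpholin-4-yl ring would fit the same pattern remains open. A single concentration also leaves any potency difference between compound 1 and compound 3 unresolved.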